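Working notes: hydroxy added to the chain of compound 2

The compounds below may be only part of what the source reports. "The series", "measured", "known", "first", "only" and "open" are said of these compounds alone.

Compound 1 `C=CCn1c(=O)n([C@H]2CO[C@@H](CO)C2)c2nc(N)nc(O)c21` gives 272 uM
Compound 2 `C=CCn1c(=O)n(CCCC)c2nc(N)nc(O)c21` gives 11 uM
Compound 3 `Cn1c(=O)n(C2OC(CI)[C@@H](O)[C@H]2O)c2nc(N)nc(O)c21` gives 52 uM

In a functional assay with Mus musculus as the target (on this read-out higher numbers stand for an effect only at larger amounts of compound and lower numbers for an effect already at smaller amounts), compound 2 has the lowest of the three numbers. Compound 4 `C=CCn1c(=O)n(CCCCO)c2nc(N)nc(O)c21` carries hydroxy in place of hydrogen on a saturated chain carbon, four bonds along the chain from an aromatic nitrogen, as counted here: hydroxy in place of hydrogen on a saturated chain carbon, four bonds along the chain from an aromatic nitrogen. Going by the values given here, the only measured step that bears on this is a 25-fold lower number from compound 1 to compound 2 (1.39 log units; beyond the scatter). That step replaces a whole ring group, so it is a loose guide. A smaller move towards a higher number is therefore expected, with an estimated step of a 3.2-fold higher number from compound 2 to compound 4 (0.50 log units; beyond the scatter). The expected value for compound 4 is 35 uM, within an estimated range of 10 uM to 120 uM.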

Compound 4, concentration for half-maximal effect: 52 uM
Beside the measured number, compound 4's estimate is 1.5-fold (0.17 log units) below it, and the stated range covers the measured number.
By their numbers in this assay, from the lowest: compound 2; then compounds 3 and 4 (each within the scatter of the next); then compound 1.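

In this assay, hydroxy in place of hydrogen on a saturated chain carbon, four bonds along the chain from an aromatic nitrogen, gives a 4.7-fold higher number from compound 2 to compound 4 (0.67 log units; beyond the scatter), so this position responds to a single added oxygen and not only to exchange of the whole group. The hydroxylated open chain still compares favourably with the ring group, at a 5.2-fold lower number from compound 1 to compound 4 (0.72 log units; beyond the scatter). No measurement at hand gives a reason for either step. From the compounds shown here alone, whether an amine or a carboxylic acid on the same chain carbon would shift the number likewise stays open, as does the effect of hydroxy on a longer chain.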